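Notes on the series: ethoxycarbonyl to methyl

The compounds below may be only part of what the source reports. "The series", "measured", "known", "first", "only" and "open" are said of these compounds alone.

The shared core is that of compound 1 `Cc1c(F)c(Oc2cccc(C(=N)N)c2)nc(Oc2cccc(C(=O)O)c2)c1F`. In an assay on isolated protein for inhibition of serine protease 1 (Bos taurus) (a lower number here means a stronger inhibitor, a higher number a weaker inhibitor), compound 1 gives > 5000 nM, which is a limit of the assay and not a number. Compound 2 `Cc1c(F)c(Oc2cccc(OC(C)C)c2)nc(Oc2cccc(C(=N)N)c2)c1F` gives 2900 nM in this assay. Among the measured compounds shown here, the one measured step, an at least 1.7-fold lower number from compound 1 to compound 2 (0.23 log units; that floor lies within the scatter), thus rests on a limit at one end and carries little weight. Compound 3 `CCOC(=O)c1ccc(N(C)C)cc1Oc1nc(Oc2cccc(C(=N)N)c2)c(F)c(C)c1F` gives > 5000 nM in this assay, again a limit of the assay rather than a number. Going by these compounds, compound 3 therefore stands at the limit of > 5000 nM in this assay, at which 2 of the 3 values shown sit, and its true value is unknown beyond that floor.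

Compound 4 `Cc1ccc(N(C)C)cc1Oc1nc(Oc2cccc(C(=N)N)c2)c(F)c(C)c1F` differs from compound 3 by methyl in place of ethoxycarbonyl on an aromatic carbon. For the measured compounds named here, no measured step touches the ring that carries the dimethylamino group; the only step with numbers changes a group on the other aryl ether, and its size is itself bounded by a limit. There is no measured basis for expecting a step beyond the scatter in this assay, in either direction. Compound 4 is expected to give about 6000 nM in this assay, within 1500 nM to 25000 nM. That estimate means a step that the limit leaves unreadable from compound 3 to compound 4 from compound 3. A value reported only as a limit is expected to be quite possible.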

Compound 4, inhibition constant: > 5000 nM
Compound 4 was reported as a limit (the forecaster's own chance of this, stated with the estimate: 55%); the middle value is on the limit's open side.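

Compound 4 gives > 5000 nM in this assay, which is a limit of the assay and not a number. With ethoxycarbonyl or with methyl on this aromatic carbon, para to a dimethylamino group, the value stays out of the readable range, so neither group gives a measurable inhibition here: the limit of > 5000 nM in this assay, at which 3 of the 4 values shown sit. Among the compounds shown here, the steps to compound 4 from compound 3 and from compound 1 cannot be read, and the one readable step, an at least 1.7-fold higher number from compound 2 to compound 4 (0.23 log units; that floor lies within the scatter), replaces a whole aryl group and so does not isolate this position.

Going by these compounds, how far compound 3 and compound 4 lie beyond the limit, and therefore the true size and direction of the change from ethoxycarbonyl to methyl, remain open. Also open, on these data alone, is whether a hydroxyl, a primary amide or a chlorine on this aromatic carbon would bring the value into the readable range, and whether any such group would do so with the dimethylamino group still in place.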